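This account rests on a few compounds, and the source may have more. Where it says the series, first, only, none or still open, it means among the compounds named here.

For the measured compounds named here, compound 2, `[O-][S+](Cc1cc(C2CC2)on1)C(c1ccccc1)c1ccccc1`, stands at the weak end of the two compounds measured so far: in an assay on HEK293 cells for inhibition of sodium-dependent dopamine transporter (Homo sapiens), read by scintillation counting, with stated times of 5 min and 1 min (a higher number here means a weaker inhibitor, a lower number a stronger inhibitor), compound 2 gives 38600 nM, the highest number of the pair. Going by the values given here, its only neighbour, compound 1, `Cc1nc(O)cc(C[S+]([O-])C(c2ccccc2)c2ccccc2)n1`, gives 3100 nM in this assay, and the single step of a 12-fold higher number from compound 1 to compound 2 (1.10 log units; beyond the scatter) shows how much the group on the saturated chain carbon bound to a sulfur can move the number.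

Compound 3, `[O-][S+](Cc1ccsc1)C(c1ccccc1)c1ccccc1`, changes that same position again: thiophen-3-yl in place of 5-cyclopropyl-1,2-oxazol-3-yl on a saturated chain carbon bound to a sulfur. Among the compounds with values here, no measured step covers a thiophen-3-yl group, so the only guide is the size of the step from compound 1 to compound 2, which says that swapping this group can shift the number by a large amount in either direction. Given that compound 2 already sits at the top of the range, a move back toward compound 1 seems at least as likely as a further rise. He therefore expects a moderate decrease, a 2.6-fold lower number from compound 2 to compound 3 (0.41 log units; beyond the scatter), with wide uncertainty. For compound 3 the estimate in this assay is 15000 nM, with a plausible range from 4000 nM to 60000 nM.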

Compound 3, half-maximal inhibitory concentration: 3000 nM
Compound 3: the middle estimate sits 5.0-fold (0.70 log units) above what was measured; measured number below the stated range.
By their numbers in this assay, from the lowest: compounds 3 and 1 (each within the scatter of the next); then compound 2.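

In this assay, thiophen-3-yl in place of 5-cyclopropyl-1,2-oxazol-3-yl on the saturated chain carbon bound to a sulfur gives a 13-fold lower number from compound 2 to compound 3 (1.11 log units; beyond the scatter), which shows that a single change at this position can bring the number down as sharply as the earlier step raised it. The further step, a 1.0-fold lower number from compound 1 to compound 3 (0.01 log units; within the scatter), lies within the scatter, so two quite different groups, thiophen-3-yl and 6-hydroxy-2-methylpyrimidin-4-yl, read alike here and, of the three groups shown, only 5-cyclopropyl-1,2-oxazol-3-yl stands apart. Nothing available explains why these groups read as they do.

Among the compounds shown, the cyclopropyl group and the 1,2-oxazole ring occur only together, so it stays open which of the two goes with the high number of compound 2. As far as these compounds go, it also stays open how this position would read with a plain phenyl ring, an amine or a carboxylic acid in place of these groups, and whether any group there could take the number clearly lower than in compound 1 and compound 3.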